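Amide aryl exchange in the series: cytotoxicity outlook

The source may report more compounds than this note shows. Statements on the series, on what has been measured and on what is new or still open speak of the compounds shown alone.

Values in an ADME assay on Li23 cells (Homo sapiens) for cytotoxicity, read by WST assay; on this read-out higher numbers stand for lower toxicity in this test and lower numbers for higher toxicity in this test:
compound 1, `CN(C(=O)c1ccccc1)c1ccc(C(O)(C(F)(F)F)C(F)(F)F)cc1`, compound 1 gives 65000 nM
compound 2, `Cc1cccc(C(=O)N(C)c2ccc(C(O)(C(F)(F)F)C(F)(F)F)cc2)c1`, compound 2 gives 20000 nM
compound 3, `CN(C(=O)c1cccnc1)c1ccc(C(O)(C(F)(F)F)C(F)(F)F)cc1`, compound 3 gives 63000 nM

Compound 1 holds the highest of the three numbers in this assay. For the measured compounds named here, compound 3 sits at essentially the same number, the step of a 1.0-fold lower number from compound 1 to compound 3 (0.01 log units; within the scatter) being within the scatter; compound 2 lies apart, the step of a 3.3-fold lower number from compound 1 to compound 2 (0.51 log units; beyond the scatter) being the only change in the set that goes beyond the scatter.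

Compound 4 `CN(C(=O)c1cccs1)c1ccc(C(O)(C(F)(F)F)C(F)(F)F)cc1` is the next member. Relative to compound 1 the change is thiophen-2-yl in place of phenyl on a carbonyl carbon.

Of the measured steps, the one that bears most directly on this change is the exchange of the aryl group on the carbonyl carbon from compound 1 to compound 3, which gave a 1.0-fold lower number from compound 1 to compound 3 (0.01 log units; within the scatter), no movement beyond the scatter. The step of a 3.2-fold higher number from compound 2 to compound 3 (0.50 log units; beyond the scatter) also exchanges the aryl group on the carbonyl carbon, but it removes a methyl at the same time. Its size matches the methyl step a 3.3-fold lower number from compound 1 to compound 2 (0.51 log units; beyond the scatter). Nothing in the set suggests that a heteroaryl group in place of phenyl on the carbonyl carbon shifts the number in this assay.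

Compound 4 is therefore expected to stay close to compound 1, with a step of a 1.1-fold lower number from compound 1 to compound 4 (0.05 log units; within the scatter), i.e. none beyond the scatter. The estimate for compound 4 in this assay is 58000 nM, expected to fall between 25000 nM and 120000 nM.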

Compound 4, half-maximal cytotoxic concentration: 33000 nM
Compound 4: the middle estimate sits 1.8-fold (0.24 log units) above what was measured; low and high end bracket the measured number.
By their numbers in this assay, from the lowest: compounds 2, 4, 3 and 1 (each within the scatter of the next, the first and the last beyond it).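

In this assay, the carbonyl carbon now also carries a five-membered aromatic ring with a sulfur atom, and every step to thiophen-2-yl stays within the scatter: a 2.0-fold lower number from compound 1 to compound 4 (0.29 log units; within the scatter), a 1.9-fold lower number from compound 3 to compound 4 (0.28 log units; within the scatter) and a 1.7-fold higher number from compound 2 to compound 4 (0.22 log units; within the scatter). Compound 4 therefore cannot be grouped with either compound 1 and compound 3 or with compound 2, even though compound 2 remains apart from the other two, so the four aryl groups do not fall into two clear levels. No measurement on hand accounts for the reading of compound 4.

Still open, on these data alone, is whether a non-aromatic group on the carbonyl carbon, such as cyclohexyl or a longer chain such as n-butyl, would keep the read-out in the range of these aryl amides. Also open, as far as these compounds go, is whether a carboxylic acid or an amine on the aryl group would move the number as the methyl group of compound 2 does, and whether a methyl group on the thiophen-2-yl ring would repeat the step seen on phenyl.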